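Swapping the benzothiazole for a smaller thiadiazole

The compounds below may be only part of what the source reports. "The series", "measured", "known", "first", "only" and "open" are said of these compounds alone.

Of the compounds shown here, two have been tested for their effect on prostate cancer cells. Compound 1 `C#CCSc1nc(Sc2nnnn2CCN(C)C)c(C#N)c(-c2cccc(Cl)c2)n1` carries a dimethylaminoethyl-tetrazolyl group on one sulfur and a chlorophenyl ring on the shared core. In a functional assay on PC-3 cells (Homo sapiens) for antiproliferative activity, read by MTT assay, with a stated time of 72 h (a higher number here means a weaker inhibitor, a lower number a stronger inhibitor), compound 1 gives 3540 nM. Compound 2 `C#CCSc1nc(Sc2nc3ccccc3s2)c(C#N)c(-c2cc(OC)c(OC)c(OC)c2)n1` instead bears a benzothiazolyl group on that sulfur and a trimethoxyphenyl ring. For compound 2 the result is only a limit of the assay, > 20000 nM, so compound 2 stands at the weak end of the two numbers shown, and this weak end is marked by the limit of > 20000 nM in this assay, at which 1 of the 2 values shown sits.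

Compound 3 `C#CCSc1nc(Sc2nncs2)c(C#N)c(-c2cc(OC)c(OC)c(OC)c2)n1` keeps everything of compound 2 except the group on the sulfur: 1,3,4-thiadiazol-2-yl in place of 1,3-benzothiazol-2-yl on a sulfur.

Since the starting point is a limit rather than a number, the size of the step in this assay is uncertain. The expected step from compound 2 to compound 3 is an at least 1.3-fold lower number from compound 2 to compound 3 (0.12 log units; that floor lies within the scatter), and compound 3 is estimated at 15000 nM, with a range from 5000 nM to 40000 nM.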

Compound 3, half-maximal inhibitory concentration: 10300 nM
Compound 3: the middle estimate sits 1.5-fold (0.16 log units) above what was measured, and the stated range covers the measured number.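

Among the compounds shown, compound 3 is the only one with the trimethoxyphenyl ring whose result in this assay is an actual number (10300 nM), so this ring can be present with activity that falls within the measurable range. Placing 1,3,4-thiadiazol-2-yl in place of 1,3-benzothiazol-2-yl on the sulfur gives an at least 1.9-fold lower number from compound 2 to compound 3 (0.28 log units; that floor lies within the scatter) in this pair, the first direct reading of a change at this position. On these data alone, that step is only a floor and its true size stays unknown, because compound 2 has a limit of the assay rather than a number: the limit of > 20000 nM in this assay, at which 1 of the 3 values shown sits.

As far as these compounds go, compound 1 differs from compound 3 in two places, so the effects of its tetrazolyl group and its chlorophenyl ring cannot be told apart, and whether the change from compound 2 to compound 3 turns on the missing six-membered ring or on the additional ring nitrogen also stays open. How a simple amine, a carboxylic acid or a longer carbon chain on this sulfur would read in this assay is likewise left open.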